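A Chloro for Fluoro Swap on the Aromatic Ring

The compounds below may be only part of what the source reports. "The series", "measured", "known", "first", "only" and "open" are said of these compounds alone.

Compound 1 `O=C(CCN1CCN(c2ccc(F)cc2)CC1)c1ccc(F)c(Br)c1`: 352000 nM
Compound 2 `O=C(CCN1CCN(c2ccc(F)cc2)CC1)c1ccc(F)c(F)c1`: 385000 nM

Among the measured compounds shown here, in an ADME assay on Vero cells (Chlorocebus sabaeus) for cytotoxicity, read by resazurin assay, with a stated time of 72 h (on this read-out higher numbers stand for weaker inhibition and lower numbers for stronger inhibition), compound 2 stands within the scatter of compound 1, the only other measured compound. Compound 3 `O=C(CCN1CCN(c2ccc(F)cc2)CC1)c1ccc(Cl)c(F)c1` is still unmeasured and differs from compound 2 by chloro in place of fluoro on an aromatic carbon, para to a large group. For the measured compounds named here, one measured step bears on this, also an exchange of one halogen for another, and it was small: a 1.1-fold higher number from compound 1 to compound 2 (0.04 log units; within the scatter). A single step is thin evidence, but it points to no shift beyond the scatter. The expected result is a 1.2-fold lower number from compound 2 to compound 3 (0.07 log units; within the scatter). For compound 3 the estimated value is 330000 nM, with an expected range of 170000 nM to 600000 nM.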

Compound 3, half-maximal inhibitory concentration: 105000 nM
The estimate for compound 3 lay 3.1-fold (0.50 log units) above the measured number, and the stated range ends above it.
By their numbers in this assay, from the lowest: compound 3; then compounds 1 and 2 (each within the scatter of the next).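

In this assay, the halogen para to a large group turns out to matter: chloro in place of fluoro gives a 3.7-fold lower number from compound 2 to compound 3 (0.56 log units; beyond the scatter), although the earlier halogen exchange stayed within the scatter. Setting 4-chloro-3-fluorophenyl in place of 3-bromo-4-fluorophenyl gives a similar a 3.4-fold lower number from compound 1 to compound 3 (0.53 log units; beyond the scatter), so the chloro compound stands apart from both of the others. These compounds leave open whether a methyl, methoxy or nitrile group at this position would also lower the number. Nothing available explains why chloro and fluoro differ here.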